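The source may hold more compounds than are shown below. What is called first, only, known or untested is meant among the compounds shown, and "the series" means these compounds.

Among the measured compounds shown here, in a functional assay on RS4-11 cells (Homo sapiens) for inhibition, read by CCK-8 assay, with a stated time of 48 h, tested at 20 uM (on this read-out higher numbers stand for more inhibition of growth at the one concentration tested and lower numbers for less inhibition of growth), compound 1 `Cc1ccc(S(=O)(=O)Oc2ccccc2/C=C(\C#N)C(=O)Nc2nnc(C)s2)cc1` gives 33% and compound 2 `Cc1ccc(S(=O)(=O)Oc2ccccc2/C=C(\C#N)C(=O)Nc2nnc(Cc3cccc(F)c3)s2)cc1` gives 56%, the higher of the two numbers so far. For the measured compounds named here, the only measured step is a number 23 percentage points higher from compound 1 to compound 2 (beyond the scatter), and it puts 3-fluorophenyl in place of hydrogen on a saturated chain carbon bound to an aromatic carbon. Compound 3 `Cc1ccc(Cc2nnc(NC(=O)/C(C#N)=C/c3ccccc3OS(=O)(=O)c3ccc(C)cc3)s2)cc1` differs from compound 2 at that same place: 4-methylphenyl in place of 3-fluorophenyl on a saturated chain carbon bound to an aromatic carbon. Here 4-methylphenyl stands in place of 3-fluorophenyl. Going by the values given here, the measured step bears on this only indirectly, since it replaces hydrogen, and no measured pair compares two such groups at this place. The expectation therefore stays close to compound 2 at 56%, with no step beyond the scatter expected. The expected change is a number 1 percentage points lower from compound 2 to compound 3 (within the scatter). For compound 3 the estimated value is 55%, with an expected range from 40% to 70%.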

Compound 3, percent growth inhibition at one concentration: 66%
Beside the measured number, compound 3's estimate is 11 percentage points below it; the measured number falls inside the stated range.
By their numbers in this assay, from the lowest: compound 1; then compounds 2 and 3 (each within the scatter of the next).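

In this assay, the change from 3-fluorobenzyl to 4-methylbenzyl is a number 10 percentage points higher from compound 2 to compound 3 (within the scatter) and so does not separate the two groups, each of which has 7 heavy atoms and one six-membered aromatic ring of carbon only. Measured against hydrogen on the saturated chain carbon, 4-methylphenyl gives a number 33 percentage points higher from compound 1 to compound 3 (beyond the scatter) and so joins 3-fluorophenyl as a second aromatic group at this place that stands beyond the scatter of compound 1. No measurement here offers an explanation for these numbers.

From the compounds shown here alone, what 4-fluorophenyl or 3-methylphenyl would give at this place stays open, so the change of substituent cannot be parted from the change in its ring position. Also open, going by these compounds, is whether a cyclohexyl group or a longer alkyl chain on that carbon would give a number like those of compound 2 and compound 3.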